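The source may hold more compounds than are shown below. What is called first, only, known or untested is meant among the compounds shown, and "the series" means these compounds.

Of the compounds shown here, three share one core and have been tested in a functional assay on MCF7 cells (Homo sapiens) for antiproliferative activity, read by MTT assay, with a stated time of 72 h; on this read-out higher numbers stand for weaker inhibition and lower numbers for stronger inhibition. Compound 1, `Cc1cccc(NC2=C/C(=N/NC(N)=S)C(=O)N=C2Nc2cccc(C)c2)c1`, gives 150 nM in this assay. Compound 3, `NC(=S)N/N=C1/C=C(Nc2ccc(F)cc2)C(Nc2ccc(F)cc2)=NC1=O`, gives 1120 nM. Compound 2, `COc1ccccc1NC1=C/C(=N/NC(N)=S)C(=O)N=C1Nc1ccccc1OC`, gives 10200 nM, the highest number of the three, with gaps to both compound 3 and compound 1 that lie beyond the usual scatter, so compound 2 is the weakest of the measured set.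

Compound 4, `COc1ccccc1NC1=C/C(=N/N=C(\N)SCc2ccccc2)C(=O)N=C1Nc1ccccc1OC`, is not yet measured. It differs from compound 2 in one place: a group of 11 heavy atoms (8 carbon, 2 nitrogen, 1 sulfur; one six-membered aromatic ring of carbon only) in place of a group of 4 heavy atoms (1 carbon, 2 nitrogen, 1 sulfur; no ring), on a double-bonded nitrogen. The two groups that are swapped share the same point of attachment, so the rest of the molecule is unchanged.

Among the measured compounds shown here, no measured pair shows this kind of exchange, so there is nothing in the data that fixes its size or direction. The expected step from compound 2 to compound 4 in this assay is therefore modest and uncertain, a 1.3-fold lower number from compound 2 to compound 4 (0.11 log units; within the scatter), and could fall within the scatter. Compound 4 is estimated at 8000 nM, with a range from 1500 nM to 40000 nM.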

Compound 4, half-maximal inhibitory concentration: 8340 nM
Beside the measured number, compound 4's estimate is 1.0-fold (0.02 log units) below it; low and high end bracket the measured number.
By their numbers in this assay, from the lowest: compound 1; then compound 3; then compounds 4 and 2 (each within the scatter of the next).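

In this assay, putting the larger group on the double-bonded nitrogen gives a 1.2-fold lower number from compound 2 to compound 4 (0.09 log units; within the scatter), so the two compounds cannot be told apart. This is the first exchange at this place among the compounds shown, and it indicates that, with the rest of compound 2 held fixed, this position tolerates a much larger group carrying a six-membered aromatic ring of carbon only, with one hydrogen-bond donor in place of two. Nothing measured here explains this outcome.

A single exchange cannot show whether other groups would be tolerated equally well at this place, such as a methyl in place of the aromatic ring-bearing part, or a chain ending in an amine or a carboxylic acid. It also leaves open whether the same exchange would have so little effect on compound 1 or compound 3.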